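The compounds below may be only part of what the source reports. "The series", "measured", "known", "first", "only" and "open" are said of these compounds alone.

Measured compounds:
- compound 1 `Cc1cn(C)nc1Nc1cc2c(c(N)n1)c(C#N)c(N1CCC[C@H]1C)n2C` gives 1290 nM
- compound 2 `C[C@@H]1CCCN1c1cc2c(N)ncnc2n1C` gives 6390 nM
- compound 3 `Cn1c(NCc2ccccc2)c(C#N)c2c(N)ncnc21` gives 3530 nM

These three compounds were tested in an assay on isolated protein for inhibition of Leucine-rich repeat serine/threonine-protein kinase 2 variant G2019S (Homo sapiens), read by TR-FRET and LanthaScreen, with stated times of 50 min and 30 min, in the presence of a further agent that is not named here; on this read-out lower numbers stand for stronger inhibition and higher numbers for weaker inhibition. Compound 1 stands at the lowest number of the three: compound 3 sits at a higher number, beyond the scatter, and compound 2 sits higher still, also beyond the scatter. Compound 1 is therefore the most potent of the measured set.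

Compound 4 `C[C@@H]1CCCN1c1c(C#N)c2c(N)nccc2n1C` has not yet been measured. It differs from compound 1 in one place: hydrogen in place of (1,4-dimethyl-1H-pyrazol-3-yl)amino on an aromatic carbon. In words, a hydrogen takes the place of the (1,4-dimethyl-1H-pyrazol-3-yl)amino group on an aromatic carbon of the shared core, with no other change.

For the measured compounds named here, no measured pair shows what this removal does. A large group carrying a hydrogen-bond donor is taken away and only a hydrogen is left, so the expectation is a move to a weaker compound, that is to a higher number in this assay, beyond the scatter. The step from compound 1 to compound 4 is expected to be a 4.7-fold higher number from compound 1 to compound 4 (0.67 log units; beyond the scatter). Compound 4 is estimated at 6000 nM, in a range from 1500 nM to 25000 nM.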

Compound 4, half-maximal inhibitory concentration: 28 nM
The estimate for compound 4 lay 210-fold (2.33 log units) above the measured number; measured number below the stated range.
By their numbers in this assay, from the lowest: compound 4; then compound 1; then compounds 3 and 2 (each within the scatter of the next).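

In this assay, replacing the (1,4-dimethyl-1H-pyrazol-3-yl)amino group with hydrogen gives a 46-fold lower number from compound 1 to compound 4 (1.66 log units; beyond the scatter). This aromatic carbon, next to the ring nitrogen, therefore needs no large substituent for strong inhibition on this core, and the bare hydrogen is far better here than the group carried by compound 1. Nothing available explains why removing the group has such a large effect.

Going by these compounds, with only these two substituents compared at this carbon, it remains open whether a small group such as methyl, methoxy or a plain amine would match hydrogen or lose strength. On these data alone, it is also open whether a methylamino group, a smaller piece of the group that left, would behave more like hydrogen or like the full group.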